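The compounds below may be only part of what the source reports. "The series", "measured", "known", "first", "only" and "open" are said of these compounds alone.

Working notes on the series. In an ADME assay on MDCKII-LE cells (Canis lupus familiaris) for permeability, in the apical to basolateral direction (on this read-out higher numbers stand for higher permeability and lower numbers for lower permeability), compound 1 `COc1ccc2c(c1O)CCCC(CCC#N)=C2c1cc(OC)c(OC)c(OC)c1` gives 19.6 10^-6 cm/s and compound 2 `COc1ccc2c(c1O)CCCC(CCCC#N)=C2c1cc(OC)c(OC)c(OC)c1` gives 16.6 10^-6 cm/s on the shared core. Between these two lies a 1.2-fold lower number from compound 1 to compound 2 (0.07 log units; within the scatter) and no order is read into it. Compound 3 `COc1ccc2c(c1O)CCCC(C)=C2c1cc(OC)c(OC)c(OC)c1` stands lowest of the three at 6.2 10^-6 cm/s on these numbers.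

Compound 4 `COc1ccc2c(c1O)CCCC(CC(O)CO)=C2c1cc(OC)c(OC)c(OC)c1` carries 1,2-dihydroxyethyl in place of hydrogen on a saturated chain carbon bound to a double-bonded ring carbon, the counted change being 1,2-dihydroxyethyl in place of hydrogen on a saturated chain carbon bound to a double-bonded ring carbon in full.

The steps bearing on this place are a 3.2-fold lower number from compound 1 to compound 3 (0.50 log units; beyond the scatter) and a 2.7-fold lower number from compound 2 to compound 3 (0.43 log units; beyond the scatter) in the same read-out. Both are modest, and both concern nitrile chains only. For the measured compounds named here, no measured compound has hydroxyl groups on this chain, and the direction of those steps is not carried over to the new group. No step beyond the scatter is expected in this assay and the range is kept wide. The expected step is a 1.2-fold lower number from compound 3 to compound 4 (0.09 log units; within the scatter) in this read-out. The estimate for compound 4 is 5 10^-6 cm/s with an expected range of 1.8 10^-6 cm/s to 14 10^-6 cm/s in this read-out.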

Compound 4, apparent permeability: 16.1 10^-6 cm/s
Estimate against measurement, compound 4: 3.2-fold (0.51 log units) below, and the stated range ends below it.
By their numbers in this assay, from the lowest: compound 3; then compounds 4, 2 and 1 (each within the scatter of the next).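

In this assay, a nitrile is not needed on this chain for the number to stand clear of compound 3: 1,2-dihydroxyethyl in place of hydrogen on a saturated chain carbon bound to a double-bonded ring carbon gives a 2.6-fold higher number from compound 3 to compound 4 (0.41 log units; beyond the scatter) as a modest step. The hydroxyl-bearing chain does not separate from the nitrile chains, with a 1.0-fold lower number from compound 2 to compound 4 (0.01 log units; within the scatter) and a 1.2-fold lower number from compound 1 to compound 4 (0.09 log units; within the scatter) as the two comparisons, so compounds 1, 2 and 4 are read as one level with no order among them. No supporting evidence is available to account for this result.

Going by these compounds, whether an amine or a carboxylic acid on this chain would hold the same level remains open. So does whether a single hydroxyl group, or a longer chain ending in hydroxyl, would do so.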